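The source may report more compounds than this note shows. Statements on the series, on what has been measured and on what is new or still open speak of the compounds shown alone.

Measured compounds:
compound 1 `Cc1c(C(=O)O)c(-c2cccc(N3CCN(c4ccc(NS(=O)(=O)c5ccc(N[C@H](CCN6CC(O)C6)CSc6ccccc6)c(S(=O)(=O)C(F)(F)F)c5)cc4)CC3)c2)c(-c2ccc(Cl)cc2)n1C` — 7.7 nM
compound 2 `CCn1c(C)c(C(=O)O)c(-c2cccc(N3CCN(c4ccc(NS(=O)(=O)c5ccc(N[C@H](CCN6CCC(O)CC6)CSc6ccccc6)c(S(=O)(=O)C(F)(F)F)c5)cc4)CC3)c2)c1-c1ccc(Cl)cc1` — 5.4 nM

In an assay for inhibition of Apoptosis regulator Bcl-2 (Homo sapiens), read by fluorescence polarization, with a stated time of 2 h (a lower number here means a stronger inhibitor, a higher number a weaker inhibitor), compound 1 gives 7.7 nM, and compound 2 gives 5.4 nM; the two values lie within the scatter of each other, so neither stands apart on the numbers shown.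

Compound 3 `Cc1c(C(=O)O)c(-c2cccc(N3CCN(c4ccc(NS(=O)(=O)c5ccc(N[C@H](CCN6CCCC6)CSc6ccccc6)c(S(=O)(=O)C(F)(F)F)c5)cc4)CC3)c2)c(-c2ccc(Cl)cc2)n1C` is not yet measured. It differs from compound 1 by pyrrolidin-1-yl in place of 3-hydroxyazetidin-1-yl on a saturated chain carbon, three bonds along the chain from a nitrogen on an aromatic ring. Among the compounds with values here, no step between measured compounds covers this change, and the two measured compounds both carry a hydroxyl on the ring at that place, so the data give no direction. The step from compound 1 to compound 3 is expected to be small, a 1.0-fold higher number from compound 1 to compound 3 (0.02 log units; within the scatter), with no change beyond the scatter in either direction. For compound 3 the estimate in this assay is 8 nM, with a range of 3 nM to 20 nM.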

Compound 3, half-maximal inhibitory concentration: 8.3 nM
The estimate for compound 3 lay 1.0-fold (0.02 log units) below the measured number; the range from low to high includes it.
By their numbers in this assay, from the lowest: compounds 2, 1 and 3 (each within the scatter of the next).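

In this assay, pyrrolidin-1-yl in place of 3-hydroxyazetidin-1-yl on this saturated chain carbon gives a 1.1-fold higher number from compound 1 to compound 3 (0.03 log units; within the scatter), so a hydroxyl on the ring is not needed here to keep the number within the scatter of compound 1. Compound 3 is the first compound shown with no hydroxyl at this place. No measurement on hand explains this result.

Ring size and hydroxyl change together in this step, so their separate contributions remain unresolved. Also open, on these data alone, is how a morpholin-4-yl group, a dimethylamino group or a carboxylic acid would read at this place.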